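Removing one ring chlorine from a purine bearing a chloromethylbenzyl group

The compounds below may be only part of what the source reports. "The series", "measured", "known", "first", "only" and "open" are said of these compounds alone.

Two compounds share a purine-like core carrying a benzyl group with a chloromethyl substituent. Compound 1 `ClCc1ccc(Cn2cnc3c(Cl)ncnc32)cc1` was tested in a functional assay on COLO 205 cells (Homo sapiens) for cytotoxicity, read by sulforhodamine B assay, with a stated time of 48 h; a higher number here means that more compound is tolerated, a lower number that less compound is tolerated. In this assay compound 1 gives > 100000 nM, which is a limit of the assay rather than a number. Among the measured compounds shown here, compound 2 `ClCc1ccccc1Cn1cnc2c(Cl)nc(Cl)nc21` is recorded in this assay as "not determined" (no result reported), so no single number marks where it stands; the only further value shown sits at the limit of > 100000 nM in this assay, at which 1 of the 2 values shown sits. Compound 3 `ClCc1ccccc1Cn1cnc2c(Cl)ncnc21` has not been measured in this assay. It differs from compound 2 by hydrogen in place of chloro on an aromatic carbon. No measured step between two compounds is available to set the size of this change, so no direction beyond the scatter can be assigned to it from the data shown. Because compound 1, which carries the same single chlorine on the core, gives > 100000 nM, compound 3 is expected to be tolerated to a similar extent. The estimate for compound 3 in this assay is 100000 nM, with a range from 30000 nM to 300000 nM.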

Compound 3, concentration lethal to 50% of the cells: > 100000 nM
Compound 3: a limit, no number (the forecaster's own chance of this, stated with the estimate: 70%); the middle value lies on the limit itself.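

In this assay compound 3 gives > 100000 nM as a limit of the assay and not a number. Among the compounds shown here, with no result reported for compound 2, no step from compound 2 to compound 3 can be read. The compounds shown leave open what exchanging chloro for hydrogen on the shared core does to the tolerated concentration, with the values resting here: the limit of > 100000 nM in this assay, at which 2 of the 3 values shown sit.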